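Urea to amide on the anilide of compound 2

A few compounds are considered here, and "the series" means these few. Any claim that something is new, unique, unknown or untested is made for them only; others in the source may bear on it.

Compound 1 `O=C(Nc1cccc(-n2cc(-c3ccncc3)c(-c3cc(O)cc(Cl)c3)n2)c1)Nc1ccc(Cl)c(C(F)(F)F)c1` gives -29.8% in a functional assay on 786-0 cells (Homo sapiens) for inhibition, read by sulforhodamine B assay, with a stated time of 48 h, tested at 10 uM; a higher number here means a weaker effect of the compound at the concentration tested, a lower number a stronger effect. Compound 2 `COc1cc(Cl)cc(-c2nn(-c3cccc(NC(=O)Nc4ccc(Cl)c(C(F)(F)F)c4)c3)cc2-c2ccncc2)c1` gives -4.76%. Compound 3 `COc1cc(Cl)cc(-c2nn(-c3cccc(NC(=O)Nc4cc(C(F)(F)F)cc(C(F)(F)F)c4)c3)cc2-c2ccncc2)c1` gives -26.9%.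

Compound 2 stands highest of the three numbers, beyond the scatter from both compound 3 and compound 1. Going by the values given here, the only step between neighbours, a number 25 percentage points higher from compound 1 to compound 2 (beyond the scatter), concerns the oxygen on the aromatic ring and not the urea. Compound 4 `COc1cc(Cl)cc(-c2nn(-c3cccc(NC(=O)c4cccc(C(F)(F)F)c4)c3)cc2-c2ccncc2)c1` differs from compound 2 by 3-(trifluoromethyl)phenyl in place of (4-chloro-3-(trifluoromethyl)phenyl)amino on a carbonyl carbon. Among the compounds with values here, no measured step touches this carbonyl carbon, and the gap between compound 2 and compound 3 shows only that a change on the terminal aryl moved the number beyond the scatter. Compound 4 is therefore expected to sit near compound 2, with a step of a number 2.8 percentage points higher from compound 2 to compound 4 (within the scatter) that may well stay within the scatter. The estimate for compound 4 is -2%, between -30% and 22%.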

Compound 4, a percentage reported as activity, at one concentration (the size of the read-out at that concentration, not a potency): 66.6%
Compound 4: middle estimate off by 68.6 percentage points, on the low side, and the stated range ends below it.
By their numbers in this assay, from the lowest: compounds 1 and 3 (each within the scatter of the next); then compound 2; then compound 4.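

In this assay, going by these compounds alone, the carbonyl carbon proves to be a sensitive position, which the earlier compounds could not show: the change gives a number 71.4 percentage points higher from compound 2 to compound 4 (beyond the scatter), and the effect at the tested concentration is weaker. This single replacement removes the amino nitrogen, with its hydrogen-bond donor, and the chlorine together, so the step belongs to the whole exchange and not to either atom alone. Nothing measured here accounts for the step.

The compounds shown leave the contributions of the amino nitrogen and the chlorine unseparated. On these data alone, it also remains open how a methylamino group on this carbonyl carbon would read.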